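From fluoro to tert-butyl on the shared core

A few compounds are considered here, and "the series" means these few. Any claim that something is new, unique, unknown or untested is made for them only; others in the source may bear on it.

Compound 1 `Nc1ccccc1NC(=O)/C=C/c1ccc(CSc2ccc(F)cc2)cc1`: 7.09%
Compound 2 `Cc1ccc(SCc2ccc(C(=O)Nc3ccccc3N)cc2)cc1`: 33.8%

In a functional assay on HeLa cells (Homo sapiens) for inhibition, read by CCK-8 assay, with a stated time of 72 h, tested at 2 uM (a higher number here means more inhibition of growth at the concentration tested, a lower number less inhibition of growth), compound 1 gives the lower of the two numbers, and compound 2 stands higher by a margin beyond the scatter. Compound 3 `CC(C)(C)c1ccc(SCc2ccc(/C=C/C(=O)Nc3ccccc3N)cc2)cc1` is compound 1 with a single change: tert-butyl in place of fluoro on an aromatic carbon. Going by the values given here, no measured pair isolates tert-butyl in place of fluoro on an aromatic carbon, so the size of this step is not known from the data. Compound 3 is expected to rise modestly above compound 1, by a step of a number 8.9 percentage points higher from compound 1 to compound 3 (within the scatter). The estimate for compound 3 is 16%, within a range from 0% to 40%.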

Compound 3, percent growth inhibition at one concentration: 17.5%
Estimate against measurement, compound 3: 1.5 percentage points below; low and high end bracket the measured number.
By their numbers in this assay, from the lowest: compound 1; then compound 3; then compound 2.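

The change from 4-fluorophenyl to 4-(tert-butyl)phenyl now has a measured size: in this assay the step is a number 10.4 percentage points higher from compound 1 to compound 3 (beyond the scatter), a modest gain. This position, para to a large group, therefore takes the larger tert-butyl without any loss of growth inhibition at the concentration tested. Nothing available explains why the number moves. Open still is how an amine or a carboxylic acid on this aromatic carbon would read, and whether the gain with tert-butyl holds on the core of compound 2.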